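This account rests on a few compounds, and the source may have more. Where it says the series, first, only, none or still open, it means among the compounds named here.

Compound 1 `O=C(c1ccc([N+](=O)[O-])cc1)n1ccnc1-c1ccccc1[N+](=O)[O-]` carries nitro groups on both aryl rings of the shared core. In an ADME assay on Vero cells (Chlorocebus sabaeus) for cytotoxicity (a lower number here means that less compound is tolerated, a higher number that more compound is tolerated), compound 1 reaches only the assay limit, > 100 ug/mL. Compound 2 `O=C(c1ccc([N+](=O)[O-])cc1)n1ccnc1-c1ccccc1Cl` differs by chloro in place of nitro on an aromatic carbon. In this assay compound 2 likewise stops at the limit, > 100 ug/mL. Compound 3 `O=C(c1ccc([N+](=O)[O-])cc1)n1ccnc1-c1ccc(Cl)cc1` has 4-chlorophenyl in place of 2-chlorophenyl on an aromatic carbon. In this assay compound 3 again gives only the limit, > 100 ug/mL. Both steps, a step that the two limits leave unreadable from compound 1 to compound 2 and a step that the two limits leave unreadable from compound 2 to compound 3, stay unreadable since (the limit of > 100 ug/mL in this assay, at which 3 of the 3 values shown sit). Compound 4 `O=C(c1ccc([N+](=O)[O-])cc1)n1ccnc1-c1ccc([N+](=O)[O-])cc1` follows with nitro in place of chloro on an aromatic carbon. The reverse of this change sits within a step that the two limits leave unreadable from compound 1 to compound 2, which sets no size for it. Compound 4 is expected at 150 ug/mL, within 100 ug/mL to 400 ug/mL. The expected step that the limit leaves unreadable from compound 3 to compound 4 is estimated to lie within the scatter.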

Compound 4, minimum cytotoxic concentration: > 100 ug/mL
Compound 4 ended at the assay's limit; the forecaster's own chance of this, stated with the estimate: 85%; the middle value does not contradict the limit.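

Among the compounds shown here, no step from compound 3 to compound 4 can be read, since both compounds stop at the assay's limit: the limit of > 100 ug/mL in this assay, at which 4 of the 4 values shown sit. In this assay the compounds shown leave open at what concentration any of them becomes cytotoxic.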